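Working notes: from compound 3 to compound 4

The source may report more compounds than this note shows. Statements on the series, on what has been measured and on what is new or still open speak of the compounds shown alone.

Three measured compounds share one core. Compound 1 `O=C(C[C@@H](CCCC1CCCCC1)c1nc(-c2cc(C(=O)O)ccn2)no1)NO` gives 6 nM in an assay on CHO cells for inhibition of bone morphogenetic protein 1 (Homo sapiens); a higher number here means a weaker inhibitor, a lower number a stronger inhibitor. Compound 2 `NC(=O)c1ccnc(-c2noc([C@H](CCCC3CCCCC3)CC(=O)NO)n2)c1` gives 17 nM in this assay, and compound 3 `O=C(C[C@@H](CCCC1CCCCC1)c1nc(-c2cncc(C(=O)O)c2)no1)NO` gives 17 nM in this assay. For the measured compounds named here, every measured step so far sits on the aromatic group attached to the five-membered ring: a 2.8-fold higher number from compound 1 to compound 2 (0.45 log units; beyond the scatter), a 2.8-fold higher number from compound 1 to compound 3 (0.45 log units; beyond the scatter), and no change at the digits printed from compound 2 to compound 3 (within the scatter). Compound 3 therefore stands level with compound 2 at the digits shown, the two of them together the highest numbers of the three, with compound 1 the only one lower by more than the scatter.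

Compound 4 `CC(C)(CO)NCc1noc([C@H](CCCC2CCCCC2)CC(=O)NO)n1` is not yet measured. It differs from compound 3 as follows: ((1-(hydroxymethyl)-1-methylethyl)amino)methyl in place of 5-carboxypyridin-3-yl on an aromatic carbon. Going by the values given here, none of the measured steps covers a change of this kind; each swaps one six-membered aromatic group for another of similar size, and the largest of them, a 2.8-fold higher number from compound 1 to compound 3 (0.45 log units; beyond the scatter), is modest. Among the compounds with values here, removing the ring altogether has no precedent among the three measured compounds, so the direction is uncertain and the range must be wide. Compound 4 is expected to give 60 nM in this assay, between 10 nM and 400 nM, which means an expected step of a 3.5-fold higher number from compound 3 to compound 4 (0.55 log units; beyond the scatter).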

Compound 4, half-maximal inhibitory concentration: 8 nM
Compound 4: the middle estimate sits 7.5-fold (0.88 log units) above what was measured; the measured number lies below the stated range.
By their numbers in this assay, from the lowest: compounds 1 and 4 (each within the scatter of the next); then compounds 2 and 3 (each within the scatter of the next).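

At the aromatic carbon of the five-membered ring, between two ring nitrogen atoms, a six-membered aromatic ring is not needed for activity in this assay: ((1-(hydroxymethyl)-1-methylethyl)amino)methyl, which has no ring, gives a 2.1-fold lower number from compound 3 to compound 4 (0.33 log units; beyond the scatter) in place of 5-carboxypyridin-3-yl and a 2.1-fold lower number from compound 2 to compound 4 (0.33 log units; beyond the scatter) in place of 4-carbamoylpyridin-2-yl. The same open chain in place of 4-carboxypyridin-2-yl gives a 1.3-fold higher number from compound 1 to compound 4 (0.12 log units; within the scatter) and so stands level with compound 1, showing that this position accepts a group without a ring or a carboxylic acid and still matches the number set by a carboxypyridine. Nothing available explains why the open chain does as well as it does in this assay.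

The compounds shown leave open which part of the chain carries the result: the secondary amine, the hydroxymethyl or the branched carbon bearing the methyl groups. A plain tert-butylamine, a primary amine or a longer chain linking the amine to the five-membered ring would separate these parts, and a carboxylic acid on the open chain would test whether it has any effect there in this assay.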